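Nitrogen substituent swap: compound 3 to compound 4

This account rests on a few compounds, and the source may have more. Where it says the series, first, only, none or still open, it means among the compounds named here.

Measured in an ADME assay on A549 cells (Homo sapiens) for cytotoxicity, read by resazurin assay, with a stated time of 48 h; a higher number here means that more compound is tolerated, a lower number that less compound is tolerated
compound 1 `CCCNc1ccc(NC(=O)c2cc(Cl)ccc2O)c(Cl)c1` gives 22500 nM
compound 2 `CC(C)CNc1ccc(NC(=O)c2cc(Cl)ccc2O)c(Cl)c1` gives 60000 nM
compound 3 `O=C(Nc1ccc(NCC2CC2)cc1Cl)c1cc(Cl)ccc1O` gives 14400 nM
compound 4 `CC1(Nc2ccc(NC(=O)c3cc(Cl)ccc3O)c(Cl)c2)CCCC1` is not yet measured

Compound 3 sits at the low end of the three numbers in this assay. One measured step to it stays inside the scatter (a 1.6-fold lower number from compound 1 to compound 3 (0.19 log units; within the scatter)) and the other goes beyond it (a 4.2-fold lower number from compound 2 to compound 3 (0.62 log units; beyond the scatter)).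

The change under review is 1-methylcyclopentyl in place of cyclopropylmethyl on a nitrogen on an aromatic ring. Going by the values given here, no measured step covers this swap directly, and only three compounds bear on it. Two steps on the same chain are the nearest guides. Methyl in place of hydrogen gave a modest rise (a 2.7-fold higher number from compound 1 to compound 2 (0.43 log units; beyond the scatter)), while cyclopropyl in place of ethyl gave nothing beyond the scatter (a 1.6-fold lower number from compound 1 to compound 3 (0.19 log units; within the scatter)).

On that basis only a small upward step is expected (a 1.7-fold higher number from compound 3 to compound 4 (0.24 log units; within the scatter)), and the direction is uncertain. The estimate for compound 4 is 25000 nM (expected range 9000 nM to 70000 nM).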

Compound 4, half-maximal cytotoxic concentration: 157000 nM
Compound 4: middle estimate off by 6.3-fold (0.80 log units), on the low side; measured number above the stated range.
By their numbers in this assay, from the lowest: compounds 3 and 1 (each within the scatter of the next); then compound 2; then compound 4.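

In this assay, going by these compounds alone, compound 4 shows that this nitrogen substituent can move the number much further than the earlier compounds suggested (an 11-fold higher number from compound 3 to compound 4 (1.04 log units; beyond the scatter)), a larger step than the widest earlier one (a 4.2-fold lower number from compound 2 to compound 3 (0.62 log units; beyond the scatter)). The rise also holds against the two other chains (a 7.0-fold higher number from compound 1 to compound 4 (0.84 log units; beyond the scatter)) (a 2.6-fold higher number from compound 2 to compound 4 (0.42 log units; beyond the scatter)), so 1-methylcyclopentyl gives the highest number of the four compounds. Nothing measured here accounts for this step.

The change brings in a ring of a different size and more carbon at once, so these compounds cannot separate the contribution of the ring from that of its methyl. As far as these compounds go, how a plain cyclopentyl or a tert-butyl on this nitrogen would compare remains open, as does the effect of an amine or a carboxylic acid on the chain.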